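The source may hold more compounds than are shown below. What is called first, only, known or untested is meant among the compounds shown, and "the series" means these compounds.

Compound 1 `O=C(CSc1nncnc1-c1ccccc1Cl)N1CCc2ccccc2C1`: >= 38000 nM
Compound 2 `COC(=O)c1ccc(NC(=O)CSc2nncnc2-c2ccccc2Cl)c(Br)c1`: 59000 nM

The two compounds share one core and differ only in the amine part of the amide. In an ADME assay on MT4 cells (Homo sapiens) for cytotoxicity, read by MTT assay (a higher number here means that more compound is tolerated, a lower number that less compound is tolerated), compound 2 gives 59000 nM, the only plain number shown. For compound 1 the value >= 38000 nM is a limit of the assay, not a number (the limit of >= 38000 nM in this assay, at which 1 of the 2 values shown sits). Compound 3 `O=C(CSc1nncnc1-c1ccccc1Cl)Nc1ccccc1Br` has not been measured; it differs from compound 2 by hydrogen in place of methoxycarbonyl on an aromatic carbon. Within the data shown here, no measured step covers such a change, so the step of a 1.1-fold lower number from compound 2 to compound 3 (0.03 log units; within the scatter) is expected to stay within the usual scatter, in no clear direction. Compound 3 is estimated at 55000 nM in this assay, between 28000 nM and 110000 nM.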

Compound 3, half-maximal cytotoxic concentration: 73000 nM
For compound 3 the middle estimate is 1.3-fold (0.12 log units) below the measured one, and the stated range covers the measured number.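

Hydrogen in place of methoxycarbonyl gives a 1.2-fold higher number from compound 2 to compound 3 (0.09 log units; within the scatter) in this assay. On this aromatic carbon, para to a large group, cells therefore tolerate the two compounds alike, and the methoxycarbonyl group is not needed for the tolerance seen with compound 2. Compound 1 still offers no number for comparison, only a limit: the limit of >= 38000 nM in this assay, at which 1 of the 3 values shown sits.

Going by these compounds, whether an amine or a carboxylic acid on the same carbon would also leave the tolerance in place remains open. So does the part played by the bromo group, which compound 2 and compound 3 share.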